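The compounds below may be only part of what the source reports. "The series", "measured", "known", "first", "only" and "open" are said of these compounds alone.

Three compounds have been measured in a functional assay on MCF7 cells (Homo sapiens) for inhibition, read by sulforhodamine B assay; a higher number here means a weaker inhibitor, a lower number a stronger inhibitor:

compound 1, `O=C1C(Nc2ccc(I)cc2)=CC(=O)c2c1nc1n2[C@H]2OC[C@@H](O)[C@H]2OC1`, gives 3890 nM.
compound 2, `COc1ccc(NC2=CC(=O)c3c(nc4n3[C@H]3OC[C@@H](O)[C@H]3OC4)C2=O)cc1`, gives 4470 nM.
compound 3, `O=C1C(N2CCC2)=CC(=O)c2c1nc1n2[C@H]2OC[C@@H](O)[C@H]2OC1`, is reported only as a limit, > 16000 nM.

Compound 3 thus stands at the weak end of the numbers shown, sitting at the limit of > 16000 nM in this assay, at which 1 of the 3 values shown sits, and no number for it is known. The two measured steps that reach it both exchange an arylamino group for azetidin-1-yl: an at least 4.1-fold higher number from compound 1 to compound 3 (0.61 log units; beyond the scatter) and an at least 3.5-fold higher number from compound 2 to compound 3 (0.55 log units; beyond the scatter). Compound 4, `O=C1C(Nc2cccc(F)c2)=CC(=O)c2c1nc1n2[C@H]2OC[C@@H](O)[C@H]2OC1`, reverses that exchange: (3-fluorophenyl)amino in place of azetidin-1-yl on a double-bonded ring carbon. Since compounds 1 and 2 carry arylamino groups and give similar numbers to each other, the step to compound 4 is expected to move in the opposite direction to those two measured steps, lowering the number beyond the scatter and bringing compound 4 back near compounds 1 and 2. The estimated step is an at least 3.8-fold lower number from compound 3 to compound 4 (0.58 log units; beyond the scatter). In this assay compound 4 is therefore expected to give about 4200 nM, with a range from 1500 nM to 12000 nM.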

Compound 4, half-maximal inhibitory concentration: > 4000 nM
Compound 4: only a limit was reported; the forecaster's own chance of this, stated with the estimate: 10%; the middle value is on the limit's open side.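

In this assay, compound 4 carries (3-fluorophenyl)amino on the double-bonded ring carbon and is reported only as a limit: the limit of > 4000 nM in this assay, at which 1 of the 4 values shown sits. Set against the arylamino group of compound 1, the result is an at least 1.0-fold higher number from compound 1 to compound 4 (0.01 log units; that floor lies within the scatter), so 3-fluorophenyl in place of 4-iodophenyl on the amine nitrogen shows no lowering of the number, though the floor of that step cannot separate the two compounds. The steps from compound 2 and from compound 3 to compound 4 cannot be read, so this third arylamino group does not confirm that such groups give lower numbers than azetidin-1-yl.

As far as these compounds go, how far compound 4 lies past its limit remains open. So does whether the limit of compound 3 belongs to azetidin-1-yl alone or would recur with a piperidin-1-yl or dimethylamino group on the same carbon.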